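From Azetidine to Chloro on a Shared Core

The source may hold more compounds than are shown below. What is called first, only, known or untested is meant among the compounds shown, and "the series" means these compounds.

Measured so far:
compound 1 `CN1CCN(c2ccn3c(-c4ccc(NC(=O)c5ccc([N+](=O)[O-])o5)cc4)cnc3c2)CC1` — 2340 nM
compound 2 `O=C(Nc1ccc(-c2cnc3cc(N4CCC4)ccn23)cc1)c1ccc([N+](=O)[O-])o1` — > 5000 nM

Compound 1 `CN1CCN(c2ccn3c(-c4ccc(NC(=O)c5ccc([N+](=O)[O-])o5)cc4)cnc3c2)CC1` and compound 2 `O=C(Nc1ccc(-c2cnc3cc(N4CCC4)ccn23)cc1)c1ccc([N+](=O)[O-])o1` share a core and differ at one aromatic carbon. In a functional assay on AGS cells (Homo sapiens) for antiproliferative activity, read by CCK-8 assay, with a stated time of 72 h (a lower number here means a stronger inhibitor, a higher number a weaker inhibitor), compound 1 gives 2340 nM. In this assay compound 2 gives > 5000 nM, which is a limit of the assay rather than a number. Compound 2 therefore stands at the limit of > 5000 nM in this assay, at which 1 of the 2 values shown sits, so its position can only be bounded from one side. Going by the values given here, the step of an at least 2.1-fold higher number from compound 1 to compound 2 (0.32 log units; beyond the scatter) is the sole measured change here.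

Compound 3 `O=C(Nc1ccc(-c2cnc3cc(Cl)ccn23)cc1)c1ccc([N+](=O)[O-])o1` has not yet been measured. It differs from compound 2 by chloro in place of azetidin-1-yl on an aromatic carbon. Among the compounds with values here, no measured step covers this change; the one known step runs from one ring amine to another, not to a halogen, so it only shows that the compound at this position can become weaker. Compound 3 is expected to remain at or near the limit, with the step that the limit leaves unreadable from compound 2 to compound 3 estimated as small. For compound 3 the expected value is 7000 nM, estimated within 2500 nM to 20000 nM.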

Compound 3, half-maximal inhibitory concentration: 1700 nM
Estimate against measurement, compound 3: 4.1-fold (0.61 log units) above; the measured number lies below the stated range.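

In this assay, the position opposite the ring nitrogen needs no ring amine for a measurable value: chloro in place of azetidin-1-yl gives an at least 2.9-fold lower number from compound 2 to compound 3 (0.46 log units; beyond the scatter). Going by these compounds, the true size of that step stays open because compound 2 is known only through a limit of the assay: the limit of > 5000 nM in this assay, at which 1 of the 3 values shown sits. Chloro in place of 4-methylpiperazin-1-yl gives a 1.4-fold lower number from compound 1 to compound 3 (0.14 log units; within the scatter), so these two groups cannot be told apart here, and of the three groups only azetidin-1-yl stands apart from the other two.

The compounds shown leave open whether a methoxy group, a fluoro group or a morpholin-4-yl ring at this position would move the number beyond the scatter from chloro. They also do not tell whether a piperazin-1-yl group without its methyl would stay level with 4-methylpiperazin-1-yl.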